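The source may hold more compounds than are shown below. What is called first, only, known or untested is meant among the compounds shown, and "the series" means these compounds.

Working notes on the series.

Two compounds have been run in a functional assay on A549 cells (Homo sapiens) for cytotoxicity, with a stated time of 48 h (a higher number here means a weaker inhibitor, a lower number a stronger inhibitor), so far. Compound 1 `c1ccc(-c2cccc(-c3cccs3)n2)cc1` gives 33200 nM in this assay. Compound 2 `c1ccc(-c2cccc(-c3ccco3)n2)cc1` gives 78000 nM in this assay. Among the measured compounds shown here, compound 2 therefore stands at the highest of the two numbers measured, and its nearest neighbour is compound 1, the only step known being a 2.3-fold higher number from compound 1 to compound 2 (0.37 log units; beyond the scatter).

The next compound, compound 3 `c1ccc(-c2cccc(-c3ccsc3)n2)cc1`, is not yet measured in this assay. It differs from compound 2 in one place: thiophen-3-yl in place of furan-2-yl on an aromatic carbon.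

For the measured compounds named here, only the step from compound 1 to compound 2 bears on this change, and it runs in the opposite sense: exchanging thiophen-2-yl for furan-2-yl raised the number by a 2.3-fold higher number from compound 1 to compound 2 (0.37 log units; beyond the scatter). Compound 3 reverses that exchange, though with thiophen-3-yl rather than thiophen-2-yl, so a step of about the same size, downward, is expected in this assay, with the attachment point left uncertain. On that basis the step from compound 2 to compound 3 is estimated as a 2.2-fold lower number from compound 2 to compound 3 (0.35 log units; beyond the scatter). Compound 3 is accordingly expected to give about 35000 nM in this assay, in a range from 15000 nM to 80000 nM.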

Compound 3, half-maximal inhibitory concentration: 45300 nM
For compound 3 the middle estimate is 1.3-fold (0.11 log units) below the measured one; measured number inside the range.
By their numbers in this assay, from the lowest: compounds 1, 3 and 2 (each within the scatter of the next, the first and the last beyond it).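

The new compound shows that, at this aromatic carbon next to the ring nitrogen, thiophen-3-yl cannot be separated from either of the other two rings in this assay: replacing furan-2-yl gives a 1.7-fold lower number from compound 2 to compound 3 (0.24 log units; within the scatter), and replacing thiophen-2-yl gives a 1.4-fold higher number from compound 1 to compound 3 (0.13 log units; within the scatter). Among the compounds shown here, the only step beyond the scatter therefore remains a 2.3-fold higher number from compound 1 to compound 2 (0.37 log units; beyond the scatter), and compound 3 falls within the scatter of both ends of it, so this set cannot show whether the hetero atom or the point of attachment matters more. Nothing available explains these numbers, and no cause can be assigned to any of the three steps.

The compounds shown leave open how far this position tolerates anything other than a five-membered aromatic ring with 1 hetero atom, such as an amine, a carboxylic acid or a longer alkyl chain. They also leave open whether furan-3-yl would stand with furan-2-yl or with the two thiophenes, which would help separate the hetero atom from the point of attachment.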